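Cytotoxicity of chalcone amides on Vero cells

The compounds below may be only part of what the source reports. "The series", "measured", "known", "first", "only" and "open" are said of these compounds alone.

Measured compounds:
compound 1, `COC(=O)c1cc(-c2cccc(NC(=O)c3ccc(/C=C/C(=O)c4ccc(Br)cc4)cc3)c2)on1`: > 20 ug/mL
compound 2, `COC(=O)c1cc(-c2cccc(NC(=O)c3ccc(/C=C/C(=O)c4ccc(C)cc4)cc3)c2)on1`: > 80 ug/mL

Of the compounds shown here, two have been tested in an ADME assay on Vero cells (Chlorocebus sabaeus) for cytotoxicity, read by MTT assay, with a stated time of 72 h; a lower number here means that less compound is tolerated, a higher number that more compound is tolerated. Compound 1, `COC(=O)c1cc(-c2cccc(NC(=O)c3ccc(/C=C/C(=O)c4ccc(Br)cc4)cc3)c2)on1`, gives in this assay > 20 ug/mL, which is a limit of the assay and not a number. Compound 2, `COC(=O)c1cc(-c2cccc(NC(=O)c3ccc(/C=C/C(=O)c4ccc(C)cc4)cc3)c2)on1`, gives in this assay > 80 ug/mL, again a limit rather than a number. The step that the two limits leave unreadable from compound 1 to compound 2, methyl in place of bromo on an aromatic carbon, therefore cannot be sized, because the limit of > 20 ug/mL in this assay, at which 1 of the 2 values shown sits, and the limit of > 80 ug/mL in this assay, at which 1 of the 2 values shown sits, both sit at limits. Compound 2 thus stands at a limit, with the other value also a limit.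

Compound 3, `COC(=O)c1cc(-c2cccc(NC(=O)c3ccc(/C=C/C(=O)c4cc(OC)c(OC)c(OC)c4)cc3)c2)on1`, has not yet been tested in this assay. It differs from compound 2 by 3,4,5-trimethoxyphenyl in place of 4-methylphenyl on a carbonyl carbon. For the measured compounds named here, no measured step bears on this change, and the only measured step is itself unreadable, so no direction beyond the scatter can be expected from the data. The author estimates for compound 3 in this assay 40 ug/mL, between 10 ug/mL and 160 ug/mL, which means an expected step of an at least 2.0-fold lower number from compound 2 to compound 3 (0.30 log units; that floor lies within the scatter).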

Compound 3, half-maximal cytotoxic concentration: > 50 ug/mL
Compound 3 was reported as a limit; the forecaster's own chance of this, stated with the estimate: 50%; middle value at least 1.2-fold (0.09 log units) from the limit.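

For the compounds shown here, compound 1, compound 2 and compound 3 are all reported only as limits of the assay, so no step among them can be read. The compounds shown leave open where each true value lies in this assay, and whether 3,4,5-trimethoxyphenyl in place of 4-methylphenyl or 4-bromophenyl changes the read-out at all.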